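Removing the Bromine: Two Cores, One Repeated Change

The compounds below may be only part of what the source reports. "The series", "measured", "known", "first", "only" and "open" are said of these compounds alone.

Compound 1 `Brc1ccc(CSc2nnc(-c3cnccn3)o2)cc1` and compound 2 `c1ccc(CSc2nnc(-c3cnccn3)o2)cc1` share a core and differ only in that (hydrogen in place of bromo on an aromatic carbon). In a functional assay on SW 1116 cells (Homo sapiens) for antiproliferative activity, read by MTT assay, with a stated time of 48 h (a lower number here means a stronger inhibitor, a higher number a weaker inhibitor), compound 1 gives 14400 nM, while compound 2 gives 34000 nM; the step is a 2.4-fold higher number from compound 1 to compound 2 (0.37 log units; beyond the scatter). Compound 3 `Brc1ccc(CSc2nnc(-c3cnccn3)s2)cc1` carries the bromo group of compound 1 on a different core; how the two cores differ is not broken down here. In this assay compound 3 gives 1470 nM, the lowest number of the three, and its steps to compound 1 and compound 2 both lie beyond the scatter. Compound 4 `c1ccc(CSc2nnc(-c3cnccn3)s2)cc1` is not yet measured and stands to compound 3 as compound 2 stands to compound 1: hydrogen in place of bromo on an aromatic carbon. The place is the same word for word in both pairs, so this is the same change. The account expects the second occurrence to behave like the first, that is a step of a 2.4-fold higher number from compound 3 to compound 4 (0.38 log units; beyond the scatter), because the earlier step was a 2.4-fold higher number from compound 1 to compound 2 (0.37 log units; beyond the scatter). Compound 4 is therefore estimated at 3500 nM, with a likely range from 1500 nM to 8000 nM.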

Compound 4, half-maximal inhibitory concentration: 7880 nM
Beside the measured number, compound 4's estimate is 2.3-fold (0.35 log units) below it; the measured number falls inside the stated range.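

Removing the bromo group from the second core again gives a weaker result in this assay, with a 5.4-fold higher number from compound 3 to compound 4 (0.73 log units; beyond the scatter). Set beside the first occurrence, the two steps run the same way and their sizes cannot be told apart: the same change on two cores in this assay, a 2.4-fold higher number (0.37 log units; beyond the scatter) from compound 1 to compound 2 and a 5.4-fold higher number (0.73 log units; beyond the scatter) from compound 3 to compound 4, 2.3-fold (0.36 log units) apart, within the scatter of two such steps. Among these compounds, in these compounds the change therefore carries from one core to the other in direction and, within the scatter, in size, but this rests on only two pairs and shows neither why the bromo group has this effect nor that the same would hold on a further core.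

The compounds shown carry only bromo or hydrogen at this place on the six-membered ring, so it remains open whether chloro, methoxy or an amine there would follow the same course on both cores. The step is also known only from this assay, which leaves open how the same change would behave in other cell lines.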